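The compounds below may be only part of what the source reports. "The series", "measured", "known", "first", "only" and "open" are said of these compounds alone.

Working notes on the series. Compound 1 `NC(=O)c1c(NC(=O)c2ccc(C(F)(F)F)cc2)sc2c1CCN(C(=S)Nc1ccccc1Cl)C2` gives 36100 nM in a functional assay on HL-60 cells (Homo sapiens) for antiproliferative activity, with a stated time of 24 h; on this read-out lower numbers stand for stronger inhibition and higher numbers for weaker inhibition. Compound 2 `NC(=O)c1c(NC(=O)c2ccc(C(F)(F)F)cc2)sc2c1CCN(C(=O)Nc1ccccc1Cl)C2` is reported in this assay only as a limit, > 50000 nM. The change from compound 1 to compound 2 is a group of 10 heavy atoms (7 carbon, 1 nitrogen, 1 oxygen, 1 chlorine; one six-membered aromatic ring of carbon only) in place of a group of 10 heavy atoms (7 carbon, 1 nitrogen, 1 sulfur, 1 chlorine; one six-membered aromatic ring of carbon only), on an amine nitrogen in a ring and it produced an at least 1.3-fold higher number from compound 1 to compound 2 (0.14 log units; that floor lies within the scatter), a floor set by the limit of > 50000 nM in this assay, at which 1 of the 3 values shown sits. Compound 3 `NC(=O)c1c(NC(=O)c2cccc([N+](=O)[O-])c2)sc2c1CCN(C(=S)Nc1ccccc1Cl)C2` differs from compound 1 in the core by 3-nitrophenyl in place of 4-(trifluoromethyl)phenyl on a carbonyl carbon; in this assay compound 3 gives 7040 nM, which is a 5.1-fold lower number from compound 1 to compound 3 (0.71 log units; beyond the scatter). Compound 4 `NC(=O)c1c(NC(=O)c2cccc([N+](=O)[O-])c2)sc2c1CCN(C(=O)Nc1ccccc1Cl)C2` is not yet measured. It differs from compound 3 by a group of 10 heavy atoms (7 carbon, 1 nitrogen, 1 oxygen, 1 chlorine; one six-membered aromatic ring of carbon only) in place of a group of 10 heavy atoms (7 carbon, 1 nitrogen, 1 sulfur, 1 chlorine; one six-membered aromatic ring of carbon only), on an amine nitrogen in a ring, the same change as from compound 1 to compound 2, made at the same place. That earlier step gave a direction but not a size because an at least 1.3-fold higher number from compound 1 to compound 2 (0.14 log units; that floor lies within the scatter) ended at the limit (the limit of > 50000 nM in this assay, at which 1 of the 3 values shown sits). Compound 4 is therefore expected to show a weakening, estimated at 20000 nM, between 8000 nM and 50000 nM, which means an expected step of a 2.8-fold higher number from compound 3 to compound 4 (0.45 log units; beyond the scatter).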

Compound 4, half-maximal inhibitory concentration: 18500 nM
Estimate against measurement, compound 4: 1.1-fold (0.03 log units) above; low and high end bracket the measured number.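

In this assay, the (2-chlorophenyl)carbamoyl group in place of its sulfur counterpart gives a 2.6-fold higher number from compound 3 to compound 4 (0.42 log units; beyond the scatter), so this change has a measured size on the second core. Both steps point to a higher number, but the earlier one gives only a floor, so this does not show that the size carries over: the same change on two cores in this assay, an at least 1.3-fold higher number (0.14 log units; that floor lies within the scatter) from compound 1 to compound 2 and a 2.6-fold higher number (0.42 log units; beyond the scatter) from compound 3 to compound 4; the limit leaves it open whether they differ The other change, 3-nitrophenyl in place of 4-(trifluoromethyl)phenyl on a carbonyl carbon, also keeps its direction, an at least 2.7-fold lower number from compound 2 to compound 4 (0.43 log units; beyond the scatter), with its size equally unsettled: the same change on two cores in this assay, a 5.1-fold lower number (0.71 log units; beyond the scatter) from compound 1 to compound 3 and an at least 2.7-fold lower number (0.43 log units; beyond the scatter) from compound 2 to compound 4; the limit leaves it open whether they differ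

The compounds shown leave open whether either step holds with another group on that carbonyl carbon, such as an unsubstituted phenyl or a longer chain. They also leave open whether the sulfur-to-oxygen step holds when an unsubstituted phenyl replaces the 2-chlorophenyl.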